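A few compounds are considered here, and "the series" means these few. Any claim that something is new, unique, unknown or untested is made for them only; others in the source may bear on it.

Measured so far:
compound 1, `COc1ccc(C(=O)/C=C/c2cc(OC)c(OC)c(OC)c2)c2c1C=CC(C)(C)O2`, gives > 10000 nM in a functional assay on HepG2 cells (Homo sapiens) for antiproliferative activity, read by MTT assay, with a stated time of 24 h (on this read-out higher numbers stand for weaker inhibition and lower numbers for stronger inhibition), which is a limit of the assay rather than a number.
compound 2, `COc1ccc(C(=O)/C=C/c2ccc(Br)cc2)c2c1C=CC(C)(C)O2`, gives > 10000 nM, also a limit.
compound 3, `COc1ccc(C(=O)/C=C/c2ccc3ccccc3n2)c2c1C=CC(C)(C)O2`, gives 4280 nM.

Compound 2 therefore stands at the limit of > 10000 nM in this assay, at which 2 of the 3 values shown sit, so it shows no measurable inhibition among the numbers here; only compound 3 gives an actual number. Compound 4, `COc1ccccc1/C=C/C(=O)c1ccc(OC)c2c1OC(C)(C)C=C2`, is not yet measured. It differs from compound 2 in one place: 2-methoxyphenyl in place of 4-bromophenyl on a double-bonded chain carbon bound to a double-bonded chain carbon. No step between two measured compounds carries this change, so nothing shown tells how it alters activity. Starting from a limit, the expected step is a step that the limit leaves unreadable from compound 2 to compound 4, no more than the usual scatter. The estimate for compound 4 in this assay is 15000 nM, with a range from 4000 nM to 60000 nM.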

Compound 4, half-maximal inhibitory concentration: > 10000 nM
Compound 4 was reported as a limit; the forecaster's own chance of this, stated with the estimate: 65%; the middle value does not contradict the limit.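

Among the compounds shown here, compound 2 and compound 4 are both reported only as a limit, not a number, so no step between them can be read: the limit of > 10000 nM in this assay, at which 3 of the 4 values shown sit. The compounds shown leave open whether 2-methoxyphenyl in place of 4-bromophenyl changes activity at all.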